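Working notes: from compound 1 to compound 4

A few compounds are considered here, and "the series" means these few. Any claim that something is new, unique, unknown or untested is made for them only; others in the source may bear on it.

In a functional assay on MCF7 cells (Homo sapiens) for inhibition, read by MTT assay, with a stated time of 3 days (a higher number here means a weaker inhibitor, a lower number a stronger inhibitor), compound 1 (`COc1cc(-c2nc3ccccc3s2)ccc1OCC(=O)NNC(=O)CN[C@@H](CS)C(=O)O`) gives 1230 nM while compound 2 (`COc1cc(-c2nc3ccccc3s2)ccc1OCC(=O)NNC(=O)CN(C(C)=O)[C@@H](CS)C(=O)O`) gives 1750 nM and compound 3 (`COc1cc(-c2nc3ccccc3s2)ccc1OCC(=O)NNC(=O)CNC(=N)NCCC[C@H](N[N+](=O)[O-])C(=O)O`) gives 1960 nM and the three values lie within the usual scatter of one another, so compound 1 stands level with the other two.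

Compound 4 (`CCOC(=O)CN(C)CC(=O)NNC(=O)COc1ccc(-c2nc3ccccc3s2)cc1OC`) has not been measured. Its change from compound 1 is ((ethoxycarbonyl)methyl)(methyl)amino in place of (1-carboxy-2-sulfanylethyl)amino on a saturated chain carbon bound to a carbonyl carbon and the shared core stays as it is.

Among the compounds with values here, one measured step bears on this part of the structure: acetyl in place of hydrogen on an amine nitrogen gives a 1.4-fold higher number from compound 1 to compound 2 (0.15 log units; within the scatter) and is small. Within the data shown here, compound 2 still carries the 1-carboxy-2-sulfanylethyl group, so no measured step shows the loss of that group. Compound 3, with a different chain, gives 1960 nM and stays within the scatter of compound 1.

A small move towards a higher number is therefore expected, with a wide margin. The estimated step in this assay is a 1.6-fold higher number from compound 1 to compound 4 (0.21 log units; within the scatter) and no large change is expected. For compound 4 the estimate is 2000 nM with an expected range from 700 nM to 6000 nM in this read-out.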

Compound 4, half-maximal inhibitory concentration: 1980 nM
Estimate against measurement, compound 4: 1.0-fold (0.00 log units) above; low and high end bracket the measured number.
By their numbers in this assay, from the lowest: compounds 1, 2, 3 and 4 (each within the scatter of the next).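

Within the data shown here, the step to ((ethoxycarbonyl)methyl)(methyl)amino on a saturated chain carbon bound to a carbonyl carbon is, in this assay, a 1.6-fold higher number from compound 1 to compound 4 (0.21 log units; within the scatter); this is the first measured step in which the 1-carboxy-2-sulfanylethyl group is gone altogether, taking with it the sulfanyl group, the free carboxy group, the defined stereocentre and the hydrogen-bond donors counted for that group, and the number stays level with that of compound 1. Read against the acetylated nitrogen, the same place gives a 1.1-fold higher number from compound 2 to compound 4 (0.05 log units; within the scatter), so among the compounds shown neither the carboxy nor the sulfanyl group is required for a number in this range, and a nitrogen bearing no hydrogen stands level with one that does. No measurement at hand accounts for this level result.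

The compounds shown do not settle whether the ethyl ester matters, since they include neither the free carboxylic acid of that chain nor a plain dimethylamino group or a longer chain at this place. All four numbers in this assay stand within the scatter of the next, so nothing here identifies a group at this place that would move the number beyond it.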